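Swapping the methoxyphenyl ketone arm for a difluorophenyl

The compounds below may be only part of what the source reports. "The series", "measured", "known", "first", "only" and "open" are said of these compounds alone.

Measured compounds in a functional assay on OVCAR-4 cells (Homo sapiens) for inhibition, read by sulforhodamine B assay, with a stated time of 48 h; on this read-out lower numbers stand for stronger inhibition of growth and higher numbers for weaker inhibition of growth:
Compound 1 `COc1ccc(C(=O)/C=C/c2cc(-c3cc(OC)c(OC)c(OC)c3)n[nH]2)cc1OC` gives 16600 nM.
Compound 2 `COc1ccc(C(=O)/C=C/c2cc(-c3cc(OC)c(OC)c(OC)c3)n[nH]2)cc1` gives 8320 nM.

Compound 1 and compound 2 share the same core and differ only in the substitution of the phenyl ring attached to the carbonyl. The step of a 2.0-fold lower number from compound 1 to compound 2 (0.30 log units; within the scatter) is the only one available, and it lies within the scatter, so compound 2 cannot be called stronger than compound 1 in this assay; the two numbers are indistinguishable on this read-out.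

Compound 3 `COc1cc(-c2cc(/C=C/C(=O)c3ccc(F)c(F)c3)[nH]n2)cc(OC)c1OC` is not yet measured. It differs from compound 2 by 3,4-difluorophenyl in place of 4-methoxyphenyl on a carbonyl carbon. Among the measured compounds shown here, the one measured step concerns a methoxy removed from a different ring, and it was within the scatter, so it offers little guidance for a change that replaces the whole ring on the carbonyl carbon. With nothing pointing either way, the expectation for compound 3 is a step of a 1.1-fold higher number from compound 2 to compound 3 (0.03 log units; within the scatter) of no size beyond the scatter, with a wide range. Compound 3 is therefore estimated at 9000 nM, between 2500 nM and 30000 nM in this assay.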

Compound 3, concentration for total growth inhibition: 71800 nM
Estimate against measurement, compound 3: 8.0-fold (0.90 log units) below, and the stated range ends below it.
By their numbers in this assay, from the lowest: compounds 2 and 1 (each within the scatter of the next); then compound 3.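

The aryl ring on the carbonyl carbon turns out to be sensitive to what it carries in this assay: the earlier change on this ring stayed within the scatter, whereas replacing 4-methoxyphenyl with 3,4-difluorophenyl gives an 8.6-fold higher number from compound 2 to compound 3 (0.94 log units; beyond the scatter), meaning weaker inhibition of growth. Starting instead from the 3,4-dimethoxyphenyl ring gives a 4.3-fold higher number from compound 1 to compound 3 (0.64 log units; beyond the scatter), also beyond the scatter, so the difluorophenyl ring compares poorly with both methoxy-bearing rings, whichever one serves as the reference. Nothing available explains why growth inhibition weakens with this swap.

These compounds leave open whether the loss follows from removing the methoxy group or from adding the fluorine atoms, since both happen in the same step; a plain phenyl ring or a phenyl ring with a single fluorine on the carbonyl carbon would help to pull those two changes apart. Also open, going by these compounds, is how this position would respond to a quite different substituent on the ring, such as an amine or a carboxylic acid.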